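Series cytotoxicity notes: from compound 2 to compound 4

The compounds below may be only part of what the source reports. "The series", "measured", "known", "first", "only" and "open" are said of these compounds alone.

Measured in an ADME assay on L02 cells (Homo sapiens) for cytotoxicity, read by MTT assay, with a stated time of 48 h; a higher number here means a weaker inhibitor, a lower number a stronger inhibitor:
- compound 1, `CCN(CC)CCNC(=O)c1ccc(C(CC)(CC)c2ccc(OCC(=O)C(C)(C)C)c(C)c2)n1CC`, gives 2500 nM
- compound 2, `CCn1c(C(=O)NCCN(C)C)ccc1C(CC)(CC)c1ccc(OCC(O)C(C)(C)C)c(C)c1`, gives 2600 nM
- compound 3, `CC[C@@H](C)[C@H](NC(=O)c1ccc(C(CC)(CC)c2ccc(OCC(=O)C(C)(C)C)c(C)c2)n1CC)C(=O)O`, gives 1500 nM

All three numbers sit close together. Compound 2 gives 2600 nM, and the numbers for compound 1 and compound 3 lie within the scatter of it, so no order among the three can be read. The only single-point step shown, a 1.7-fold lower number from compound 1 to compound 3 (0.22 log units; within the scatter), swaps the substituent on the amide-type nitrogen and stays within the scatter.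

Compound 4, `CCn1c(C(=O)Oc2ccc(CCO)cc2)ccc1C(CC)(CC)c1ccc(OCC(O)C(C)(C)C)c(C)c1`, is not yet measured. Its change from compound 2 is a group of 10 heavy atoms (8 carbon, 2 oxygen; one six-membered aromatic ring of carbon only) in place of a group of 6 heavy atoms (4 carbon, 2 nitrogen; no ring), on a carbonyl carbon. Within the data shown here, this is a larger change than the one from compound 1 to compound 3, and it alters the attachment on the carbonyl carbon rather than the substituent on the nitrogen, so that step bears on it only loosely. With three compounds of similar values and no shown step leaving the scatter, no step beyond the scatter is expected in this assay.

Compound 4 is therefore estimated at 2500 nM, with a range of 1100 nM to 6000 nM. The expected step is a 1.0-fold lower number from compound 2 to compound 4 (0.02 log units; within the scatter).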

Compound 4, half-maximal inhibitory concentration: 22700 nM
Beside the measured number, compound 4's estimate is 9.1-fold (0.96 log units) below it, outside the stated range (above it).
By their numbers in this assay, from the lowest: compounds 3, 1 and 2 (each within the scatter of the next); then compound 4.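

In this assay, among these compounds, the change on the carbonyl carbon gives an 8.7-fold higher number from compound 2 to compound 4 (0.94 log units; beyond the scatter) and is the only step so far that leaves the scatter. Among the compounds shown here, the step of a 1.7-fold lower number from compound 1 to compound 3 (0.22 log units; within the scatter) stays within the scatter but changes the substituent on an amide-type nitrogen, so only this new step shows that the number can respond to replacing the (2-(dimethylamino)ethyl)amino group on the carbonyl carbon. Nothing available explains this step.

The single swap removes both nitrogens and brings in the aromatic ring, so the compounds shown do not separate the contributions of these parts. A methyl ester or a carboxylic acid at this carbonyl carbon, or an amide carrying a simple phenyl group, would help to divide the step among them.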